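This account rests on a few compounds, and the source may have more. Where it says the series, first, only, none or still open, it means among the compounds named here.

For the measured compounds named here, in a physicochemical assay, read by spectrophotometry, with a stated time of 30 min (on this read-out lower numbers stand for stronger inhibition and higher numbers for weaker inhibition), compound 2 (`O=C(CCCc1nc2ccccc2c(=O)[nH]1)N/N=C/c1ccc(Cl)cc1`) gives 353000000 nM, the higher of the two numbers so far, and compound 1 (`O=C(CCCc1nc2ccccc2c(=O)[nH]1)N/N=C/c1cc(O)c(O)c(O)c1`) gives 78000000 nM as its nearest neighbour. Compound 3 (`O=C(CCCc1nc2ccccc2c(=O)[nH]1)N/N=C/c1ccc(O)cc1`) is still unmeasured. The change is hydroxy in place of chloro on an aromatic carbon and reads as hydroxy in place of chloro on an aromatic carbon, that is, 4-chlorophenyl to 4-hydroxyphenyl. Going by the values given here, one measured step bears on it: a 4.5-fold higher number from compound 1 to compound 2 (0.66 log units; beyond the scatter), a modest step that replaced 3,4,5-trihydroxyphenyl with 4-chlorophenyl. Among the compounds with values here, no measured step isolates a single hydroxy. A partial return towards compound 1 is therefore expected, meaning a lower number in this assay and a step smaller than that one. The expected step is a 2.2-fold lower number from compound 2 to compound 3 (0.34 log units; beyond the scatter), small and downward. For compound 3 the estimated value is 160000000 nM, with an expected range of 70000000 nM to 360000000 nM.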

Compound 3, half-maximal inhibitory concentration: 214000000 nM
Compound 3: the middle estimate sits 1.3-fold (0.13 log units) below what was measured; the measured number falls inside the stated range.
By their numbers in this assay, from the lowest: compound 1; then compounds 3 and 2 (each within the scatter of the next).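

In this assay, hydroxy and chloro on the aromatic carbon para to a large group cannot be told apart (a 1.6-fold lower number from compound 2 to compound 3 (0.22 log units; within the scatter)), so this single exchange gives no measurable handle at this position. The separation from compound 1 remains with a hydroxy in place (a 2.7-fold higher number from compound 1 to compound 3 (0.44 log units; beyond the scatter)), which shows that 4-hydroxyphenyl alone does not reproduce the number given by 3,4,5-trihydroxyphenyl. The difference between the aryl groups of compound 1 and compound 2 therefore cannot be assigned to the group at this one carbon, and it stays tied to the full 3,4,5-trihydroxyphenyl pattern.

Still open, going by these compounds, is whether a 3,4-dihydroxyphenyl group would close part of the remaining gap, and whether an amine or a carboxylic acid at this carbon would separate from hydroxy and chloro. No measurement at hand explains any of these numbers.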